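Swapping Methoxymethyl for Diethylcarbamoyl on a Side Chain

This account rests on a few compounds, and the source may have more. Where it says the series, first, only, none or still open, it means among the compounds named here.

Three compounds with a shared core frame this question in an ADME assay on BJ cells (Homo sapiens) for cytotoxicity, with a stated time of 72 h; on this read-out lower numbers stand for an effect already at smaller amounts and higher numbers for an effect only at larger amounts of compound. For compound 1 `COc1cc2ncnc(-n3nc(-c4ccccn4)nc3N)c2cc1N` the entry is "not determined" (no result reported). Compound 2 `COc1cc2ncnc(-n3nc(-c4ccccn4)nc3N)c2cc1OCCCN1CC(C)OC(C)C1` gives > 25000 nM, which is a limit of the assay and not a number. Compound 3 `COCCOc1cc2c(-n3nc(-c4ccccn4)nc3N)ncnc2cc1OC` gives > 13000 nM, which is also only a limit. Among the measured compounds shown here, the one measured step is a step that the two limits leave unreadable from compound 2 to compound 3. Compound 4 `CCN(CC)C(=O)COc1cc2c(-n3nc(-c4ccccn4)nc3N)ncnc2cc1OC` carries diethylcarbamoyl in place of methoxymethyl on a saturated chain carbon bound to an oxygen on an aromatic ring. For the measured compounds named here, with only that unreadable step as a guide, no step beyond the usual scatter is expected in this assay, and another limit is likely. The estimate means an expected step that the limit leaves unreadable from compound 3 to compound 4. Compound 4 is expected near 20000 nM, within an estimated range of 8000 nM to 50000 nM.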

Compound 4, half-maximal effective concentration: > 25000 nM
Compound 4: no number, only a limit; the forecaster's own chance of this, stated with the estimate: 75%; middle value at least 1.2-fold (0.09 log units) from the limit.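

Like compound 2 and compound 3, compound 4 gives only a limit of the assay and not a number, so no step among these three compounds can be read. As far as these compounds go, the amount of each that produces an effect in this assay stays open.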